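The compounds below may be only part of what the source reports. "The series", "measured", "known", "first", "only" and "open" are said of these compounds alone.

Measured compounds so far:
compound 1, `NC(=S)c1c(N)n(COCc2ccccc2)c2ncnc(N)c12` — in a functional assay on KB cells (Homo sapiens) for inhibition (a lower number here means a stronger inhibitor, a higher number a weaker inhibitor), compound 1 gives 225000 nM
compound 2, `COCCOCn1c(N(C)C)c(C#N)c2c(N)ncnc21` — compound 2 gives > 100000 nM, a limit of this assay rather than a number
compound 3, `CCCn1c(N)c(C#N)c2c(N)ncnc21` — compound 3 gives 15000 nM

Compound 3 stands lowest of the two numbers in this assay; the nearest number, that of compound 1, is higher by a gap beyond the usual scatter. The value of compound 2 is only a limit: the limit of > 100000 nM in this assay, at which 1 of the 3 values shown sits. No two of these compounds differ in a single place, so no measured step is available within the series.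

Compound 4, `CCOCn1c(N)c(C#N)c2c(N)ncnc21`, is not yet measured. It differs from compound 3 by ethoxy in place of ethyl on a saturated chain carbon bound to an aromatic nitrogen. Compounds 1 and 2, which also carry an ether chain on that carbon, differ from compound 3 in further places as well and so give no clean reading of this change. The step from compound 3 to compound 4 in this assay is expected to be small, toward a higher number, at about the edge of the scatter: a 2.0-fold higher number from compound 3 to compound 4 (0.30 log units; within the scatter). For compound 4 the expected value is 30000 nM, with a range from 8000 nM to 150000 nM.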

Compound 4, half-maximal inhibitory concentration: 138000 nM
Beside the measured number, compound 4's estimate is 4.6-fold (0.66 log units) below it; the range from low to high includes it.
By their numbers in this assay, from the lowest: compound 3; then compounds 4 and 1 (each within the scatter of the next).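

In this assay, among these compounds, this pair gives the first clean reading at the saturated chain carbon bound to an aromatic nitrogen: a 9.2-fold higher number from compound 3 to compound 4 (0.96 log units; beyond the scatter) with ethoxy in place of ethyl, the same difference as propyl to ethoxymethyl. The position therefore responds to this change, by a margin beyond the scatter, and inhibition is weaker with the ether chain on the shared core. This remains a single pair rather than a trend, and no measured property in the data accounts for the step.

From the compounds shown here alone, whether the step follows from the ether oxygen itself or from the added chain atom stays open. The compounds shown include no chain carrying an amine or a carboxylic acid and no butyl chain at this position, so the response to such groups cannot be told.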